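The compounds below may be only part of what the source reports. "The series", "measured", "known", "first", "only" and "open" are said of these compounds alone.

In an ADME assay on a cell-free system (plasma, Homo sapiens) for protein binding, compound 1 `Cc1cc(Nc2ccc(S(F)(F)(F)(F)F)cc2)n2nc(C3CC3)nc2n1` gives 97.7%, while compound 2 `COCCc1nc2nc(C)cc(Nc3ccc(S(F)(F)(F)(F)F)cc3)n2n1` gives 87.7%. Among the compounds with values here, the single change on the shared core produced a 5.3-fold higher unbound fraction from compound 1 to compound 2 (0.73 log units; beyond the scatter). Among the two compounds measured so far, compound 2 therefore has the highest unbound fraction, with compound 1 as its only neighbour.

Compound 3 `CSc1nc2nc(C)cc(Nc3ccc(S(F)(F)(F)(F)F)cc3)n2n1` has not yet been measured in this assay. It differs from compound 2 in one place: methylsulfanyl in place of 2-methoxyethyl on an aromatic carbon. Within the data shown here, the only measured step that touches this same place is a 5.3-fold higher unbound fraction from compound 1 to compound 2 (0.73 log units; beyond the scatter), where a group of four heavy atoms replaced the cyclopropyl there. Removing the 2-methoxyethyl again and putting a two-atom methylsulfanyl group in its place is expected to move the binding back toward the value of compound 1, giving a 2.5-fold lower unbound fraction from compound 2 to compound 3 (0.39 log units; beyond the scatter). For compound 3 the estimate is 95%, with the range from 90% to 98%.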

Compound 3, plasma protein binding in the plasma assay: 97.7%
The estimate for compound 3 lay 2.2-fold (0.34 log units) (unbound fraction) above the measured number; measured number inside the range.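

In the plasma assay methylsulfanyl undoes the whole gain of 2-methoxyethyl, with a 5.3-fold lower unbound fraction from compound 2 to compound 3 (0.73 log units; beyond the scatter), and with no change at the digits printed from compound 1 to compound 3 (within the scatter), so cyclopropyl and methylsulfanyl cannot be told apart here and only 2-methoxyethyl of the three stands out. In a physicochemical assay for lipophilicity, at pH 7.4 (a higher number here means a more lipophilic compound, a lower number a more polar compound), compound 2 gives 3 and compound 3 gives 3.5. A possible cause of the stronger protein binding of compound 3 is its higher lipophilicity, a reading that rests on this one pair: the measured distribution coefficient of compound 2, 3, and of compound 3, 3.5, a number 0.50 log units higher (beyond the scatter)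

The compounds shown leave open whether the oxygen of 2-methoxyethyl or the length of its chain matters for the higher unbound fraction of compound 2. An amine or a carboxylic acid on this aromatic carbon would show how far the plasma assay can move beyond the values seen so far.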